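Swapping bromophenyl substitution pattern on a shared amide core

A few compounds are considered here, and "the series" means these few. Any claim that something is new, unique, unknown or untested is made for them only; others in the source may bear on it.

Of the compounds shown here, two with a shared core have been measured so far. Compound 1 `COc1cc2c(Oc3ccc(NC(=O)c4nn(-c5ccccc5Br)c(=O)c5ccccc45)cc3F)ccnc2cc1OCCCN1CCN(C)CC1` gives 290 nM in a functional assay on NCI-H460 cells (Homo sapiens) for cytotoxicity, read by MTT assay, with a stated time of 72 h; a lower number here means a stronger inhibitor, a higher number a weaker inhibitor. Compound 2 `COc1cc2c(Oc3ccc(NC(=O)c4nn(-c5ccc(Br)cc5)c(=O)c5ccccc45)cc3F)ccnc2cc1OCCCN1CCC(C)CC1` gives 350 nM in this assay; compound 2 stands alongside compound 1, the two values lying within the usual scatter of each other, so neither can be called the stronger of the pair. Compound 3 `COc1cc2c(Oc3ccc(NC(=O)c4nn(-c5ccccc5Br)c(=O)c5ccccc45)cc3F)ccnc2cc1OCCCN1CCC(C)CC1` has not yet been measured. It differs from compound 2 in one place: 2-bromophenyl in place of 4-bromophenyl on an aromatic nitrogen. Within the data shown here, no single-change pair between measured compounds is available to guide the size of this step. Given that compound 1, which also carries 2-bromophenyl, gives 290 nM, the step from compound 2 to compound 3 is expected to be a 1.2-fold lower number from compound 2 to compound 3 (0.07 log units; within the scatter), none beyond the scatter. Compound 3 is therefore estimated at 300 nM in this assay, with a range from 150 nM to 600 nM.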

Compound 3, half-maximal inhibitory concentration: 390 nM
Estimate against measurement, compound 3: 1.3-fold (0.11 log units) below, within the range that was stated.
By their numbers in this assay, from the lowest: compounds 1, 2 and 3 (each within the scatter of the next).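

In this assay, the direct comparison of 2-bromophenyl with 4-bromophenyl on the aromatic nitrogen gives a 1.1-fold higher number from compound 2 to compound 3 (0.05 log units; within the scatter), so this change of bromine placement has no readable effect with 4-methylpiperidin-1-yl at the chain end. With 2-bromophenyl held fixed, 4-methylpiperidin-1-yl in place of 4-methylpiperazin-1-yl gives a 1.3-fold higher number from compound 1 to compound 3 (0.13 log units; within the scatter), so the chain-end change also has no readable effect in this pair. No measurement is available that could explain either result.

The compounds shown leave open whether the same holds for 4-bromophenyl combined with 4-methylpiperazin-1-yl. They also leave open whether an unsubstituted phenyl or a 2-methoxyphenyl group on the aromatic nitrogen, or a morpholine at the chain end, would shift the value beyond the scatter.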